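Tert-butoxy in place of tert-butyl on a high-exposure compound

This account rests on a few compounds, and the source may have more. Where it says the series, first, only, none or still open, it means among the compounds named here.

So far, two compounds sharing a core have been followed in an ADME assay on the whole organism (Mus musculus) for pharmacokinetics, at a dose of 50 mg/kg by the oral route (on this read-out higher numbers stand for higher exposure at the dose given and lower numbers for lower exposure), at this oral dose. Compound 1 (`CC(=O)NCCS(=O)(=O)c1ccc(S(=O)(=O)c2ccc(CN)s2)cc1`) gives 145 ng.h/mL in this measurement. Compound 2 (`CC(C)(C)c1cc(S(C)(=O)=O)cc(S(=O)(=O)c2ccc(CN)s2)c1`) gives 2520 ng.h/mL as the higher of the two numbers, and the gap between them lies beyond the usual scatter. Among the measured compounds shown here, these two compounds differ in more than one place, so no measured step speaks directly to the next change.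

Compound 3 (`CC(C)(C)Oc1cc(S(C)(=O)=O)cc(S(=O)(=O)c2ccc(CN)s2)c1`) has not yet been measured in this assay and departs from compound 2 at a single place. It carries tert-butoxy in place of tert-butyl on an aromatic carbon, meta to a methylsulfonyl group (tert-butoxy in place of tert-butyl on an aromatic carbon). Compound 2, at 2520 ng.h/mL as its closest measured neighbour, anchors the expectation, and the direction of the change remains uncertain. The estimated step of a 1.4-fold lower number from compound 2 to compound 3 (0.15 log units; within the scatter) is a slight fall that stays within the scatter. For compound 3 the expected value is 1800 ng.h/mL (600 ng.h/mL to 5000 ng.h/mL).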

Compound 3, area under the concentration-time curve: 928 ng.h/mL
Estimate against measurement, compound 3: 1.9-fold (0.29 log units) above, and the stated range covers the measured number.
By their numbers in this assay, from the lowest: compound 1; then compound 3; then compound 2.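

Replacing tert-butyl with tert-butoxy on an aromatic carbon, meta to a methylsulfonyl group, gives a 2.7-fold lower number from compound 2 to compound 3 (0.43 log units; beyond the scatter) in this assay, a modest fall that lies beyond the usual scatter. Among the compounds shown here, this is the first comparison that isolates a single place, since compounds 1 and 2 differ in more than one. It shows that oral exposure in the mouse responds to what sits at this position, even when the entering group keeps the four carbons of tert-butyl and adds only an oxygen. Nothing measured in this set of compounds accounts for the fall in exposure.

As far as these compounds go, a single step cannot separate a contribution of the oxygen from that of the tert-butoxy group as a whole, so it remains open whether a smaller ether such as methoxy, a longer chain such as isobutyl, or an amine on the same carbon would give higher or lower exposure. From the compounds shown here alone, it also remains open whether the same fall would appear with something other than the methylsulfonyl group elsewhere on that ring, such as a nitrile.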